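Two Phenyl Sulfonamides Tested Against One Dehydrogenase

A few compounds are considered here, and "the series" means these few. Any claim that something is new, unique, unknown or untested is made for them only; others in the source may bear on it.

The read-out here is an assay for binding affinity to 17-beta-hydroxysteroid dehydrogenase type 2 (Homo sapiens), with a stated time of 20 min, tested at 1 uM; on this read-out lower numbers stand for less inhibition and higher numbers for more inhibition at the one concentration tested (going by the name of the read-out). Compound 1, with the structure `Oc1cccc(-c2ccc3ccccc3c2)c1`, gives 12%. Compound 2, with the structure `Cc1cccc(S(=O)(=O)Nc2ccc(-c3ccc(CO)cc3)cc2)c1`, gives 12%. Compound 2 therefore stands level with compound 1 at the digits shown, and the two values lie within the usual scatter of each other, so the inhibition in this assay is level for the pair.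

Compound 3, with the structure `Cc1cccc(S(=O)(=O)Nc2ccc(-c3ccc(O)cc3)cc2)c1`, has not yet been measured. It differs from compound 2 in one place: hydroxy in place of hydroxymethyl on an aromatic carbon. The change sits on an aromatic carbon of a six-membered aromatic ring of carbon only, and it trims the hydroxymethyl group to a bare hydroxy group.

Both measured compounds sit low on this read-out, and the change between compound 2 and compound 3 is small in size. The expected step from compound 2 to compound 3 is therefore a number 3 percentage points higher from compound 2 to compound 3 (within the scatter), which is none beyond the scatter. Compound 3 is estimated to give 15%, with a likely range from 0% to 40% in this assay.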

Compound 3, a percentage reported as inhibition, at one concentration (the size of the read-out at that concentration, not a potency): 14%
For compound 3 the middle estimate is 1 percentage points above the measured one, and the stated range covers the measured number.
By their numbers in this assay, from the lowest: compounds 1, 2 and 3 (each within the scatter of the next).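

Going from 4-(hydroxymethyl)phenyl to 4-hydroxyphenyl, on an aromatic carbon para to a large group, gives in this assay a number 2 percentage points higher from compound 2 to compound 3 (within the scatter), so this trim does not separate the two compounds on this read-out. Among these compounds, this is the first pair that differs in only one place, and both of its members sit low at the single concentration tested, so it shows only that this small edit keeps the read-out in the same low range, not that the position is unimportant for inhibition. Nothing given here bears on why the two compounds read alike.

Hydroxymethyl and hydroxy are close relatives, each with one hydrogen-bond donor and one acceptor, so this pair explores only a narrow slice of what could sit at this position. From the compounds shown here alone, whether a clearly different group there, such as an amine, a carboxylic acid or a longer chain ending in hydroxy, would lift inhibition beyond the scatter remains open, as does what a change elsewhere on the shared core would do.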